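This account rests on a few compounds, and the source may have more. Where it says the series, first, only, none or still open, it means among the compounds named here.

Three analogues of the shared core have a number in a functional assay on RXF 393 cells (Homo sapiens) for inhibition (a higher number here means a weaker inhibitor of growth, a lower number a stronger inhibitor of growth), so far. Compound 1 `COc1cc(/C=C/C(=O)c2cccc(-n3cc(-c4ccc(Cl)cc4)[nH]c3=O)c2)cc(OC)c1OC` gives 3220 nM; compound 2 `COc1cc(/C=C/C(=O)c2cccc(-n3cc(-c4ccccc4)[nH]c3=O)c2)ccc1O` gives 2270 nM; compound 3 `O=C(/C=C/c1cccc(O)c1)c1cccc(-n2cc(-c3ccccc3)[nH]c2=O)c1` gives 1890 nM. Compound 2 stands second highest of the three, and its gaps to compound 3 and to compound 1 both lie within the scatter. Within the data shown here, the one single-place step among them, a 1.2-fold lower number from compound 2 to compound 3 (0.08 log units; within the scatter), is within the scatter as well. Compound 4 `COc1ccc(-c2cn(-c3cccc(C(=O)/C=C/c4ccc(O)c(OC)c4)c3)c(=O)[nH]2)cc1` carries methoxy in place of hydrogen on an aromatic carbon. Among the measured compounds shown here, no measured step bears on this change; compound 1, which differs from compound 2 on that ring and elsewhere, shows a value within the scatter of compound 2. A step of a 1.0-fold higher number from compound 2 to compound 4 (0.01 log units; within the scatter) is therefore expected, none beyond the scatter. Compound 4 is estimated at 2300 nM in this assay, between 1000 nM and 5200 nM.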

Compound 4, concentration for 50% growth inhibition: 5850 nM
Beside the measured number, compound 4's estimate is 2.5-fold (0.41 log units) below it; the whole stated range lies below it.
By their numbers in this assay, from the lowest: compounds 3, 2, 1 and 4 (each within the scatter of the next, the first and the last beyond it).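

In this assay, among these compounds, the change of phenyl to 4-methoxyphenyl gives a 2.6-fold higher number from compound 2 to compound 4 (0.41 log units; beyond the scatter) and so is the first single-place change beyond the scatter. Methoxy on this aromatic carbon, para to a large group, therefore moves the number toward weaker growth inhibition, whereas the only earlier single-place step, made elsewhere in the molecule, stayed within the scatter. No evidence is available on what lies behind this step.

Going by these compounds, whether fluorine, an amine or a carboxylic acid at this position would shift the number as methoxy does remains open. So does whether the methoxy step would recur with the 3-hydroxyphenyl group of compound 3.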